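A Ring Nitrogen Swap at the Fluoro Position of Compound 2

A few compounds are considered here, and "the series" means these few. Any claim that something is new, unique, unknown or untested is made for them only; others in the source may bear on it.

Three ureas sharing one core have been measured in a functional assay on HepG2 cells (Homo sapiens) for cytotoxicity, read by MTT assay, with a stated time of 72 h; a higher number here means a weaker inhibitor, a lower number a stronger inhibitor. Compound 1 `O=C(Nc1ccc(-n2ncc3c(C(F)(F)F)cccc32)cc1)Nc1ccc(Cl)c(C(F)(F)F)c1` gives 8000 nM, compound 2 `O=C(Nc1ccc(-n2ncc3c(F)cccc32)cc1)Nc1ccc(Cl)c(C(F)(F)F)c1` gives 29500 nM, and compound 3 `CNc1cccc2c1cnn2-c1ccc(NC(=O)Nc2ccc(Cl)c(C(F)(F)F)c2)cc1` gives 3000 nM. Compound 2 thus stands highest of the three numbers, its nearest neighbour being compound 1 and its furthest compound 3. All measured steps concern the same aromatic carbon of the bicyclic arm: a 3.7-fold higher number from compound 1 to compound 2 (0.57 log units; beyond the scatter), a 2.7-fold lower number from compound 1 to compound 3 (0.43 log units; beyond the scatter) and a 9.8-fold lower number from compound 2 to compound 3 (0.99 log units; beyond the scatter). Compound 4 `O=C(Nc1ccc(-n2ncc3cnccc32)cc1)Nc1ccc(Cl)c(C(F)(F)F)c1` has not yet been measured. It differs from compound 2 in that (a group of 9 heavy atoms (6 carbon, 3 nitrogen; one five-membered aromatic ring with 2 hetero atoms, one six-membered aromatic ring with 1 hetero atom) in place of a group of 10 heavy atoms (7 carbon, 2 nitrogen, 1 fluorine; one five-membered aromatic ring with 2 hetero atoms, one six-membered aromatic ring of carbon only), on an aromatic carbon). None of the three steps matches this change exactly, since each swaps one substituent for another, whereas compound 4 loses the fluorine and instead carries a hetero atom within the six-membered ring. What the steps do show is that compound 2 carries the least favourable of the three groups tried at that place, so a move away from it seems more likely to lower the number than to raise it. A modest fall is therefore expected, a 2.5-fold lower number from compound 2 to compound 4 (0.39 log units; beyond the scatter). Compound 4 is estimated at 12000 nM, with a range from 3500 nM to 40000 nM.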

Compound 4, half-maximal inhibitory concentration: 4000 nM
The estimate for compound 4 lay 3.0-fold (0.48 log units) above the measured number; the measured number falls inside the stated range.
By their numbers in this assay, from the lowest: compounds 3, 4 and 1 (each within the scatter of the next, the first and the last beyond it); then compound 2.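

In this assay, a 7.4-fold lower number from compound 2 to compound 4 (0.87 log units; beyond the scatter), a step that, unlike the earlier ones, does not swap one substituent on the aromatic carbon for another but removes the fluoro group and places a nitrogen within the six-membered ring. It shows that the high number of compound 2 can be left behind without any trifluoromethyl or methylamino group, since compound 4 lies within the scatter of both compound 1 and compound 3, and the three cannot be ordered among themselves. No measurement is available here that would explain why this change lowers the number.

The compounds shown leave open how much of this step belongs to the loss of the fluoro group and how much to the ring nitrogen, a question that a plain hydrogen on the same carbon of the all-carbon ring would address. They also leave open whether a substituent such as an amine or a carboxylic acid on the nitrogen-containing ring would move the number any further from that of compound 4.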